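The source may hold more compounds than are shown below. What is called first, only, known or untested is meant among the compounds shown, and "the series" means these compounds.

Measured compounds and their values in an ADME assay on A549 cells (Homo sapiens) for cytotoxicity; on this read-out higher numbers stand for weaker inhibition and lower numbers for stronger inhibition:
compound 1, `O=C(/C=C/c1ccc2c(C(F)(F)F)cccc2n1)c1ccncc1`, 45400 nM
compound 2, `O=C(/C=C/c1ccc2ccc(C(F)(F)F)cc2n1)c1ccccn1`, 10200 nM
compound 3, `O=C(/C=C/c1ccccn1)c1ccc2ccc(C(F)(F)F)cc2n1`, 11200 nM

Of these three numbers, compound 1 stands highest in this assay with 45400 nM. Compound 3 comes nearest, its 11200 nM lying beyond the scatter below it, and compound 2 sits furthest with 10200 nM, also beyond the scatter. Compound 4, `O=C(/C=C/c1ccc2c(C(F)(F)F)cccc2n1)c1cccnc1`, has the same atoms as compound 1 joined differently: pyridin-3-yl in place of pyridin-4-yl on a carbonyl carbon. Within the data shown here, no measured pair here shares this change, so the account has no step to lean on; a move in this assay from compound 1 to compound 4 of no more than the scatter, in either direction, is expected. The step of a 1.1-fold lower number from compound 1 to compound 4 (0.05 log units; within the scatter) is therefore estimated as small. Compound 4 is expected to give 40000 nM, in the range 15000 nM to 110000 nM.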

Compound 4, half-maximal inhibitory concentration: > 50000 nM
Compound 4: no number, only a limit; the forecaster's own chance of this, stated with the estimate: 15%; middle value at least 1.2-fold (0.09 log units) from the limit.
By their numbers in this assay, from the lowest: compounds 2 and 3 (each within the scatter of the next); then compound 1. At a limit, above all of these: compound 4.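

In this assay, compound 4 gives > 50000 nM, which is a limit of the assay and not a number. Pyridin-3-yl in place of pyridin-4-yl on a carbonyl carbon gives an at least 1.1-fold higher number from compound 1 to compound 4 (0.04 log units; that floor lies within the scatter), the first step read at this position, and only its floor is known, so its true size cannot be read. For compound 4 the reading rests on a limit: the limit of > 50000 nM in this assay, at which 1 of the 4 values shown sits.

As far as these compounds go, whether this change would act the same way on the core of compound 2 remains open. So does how an amine or a phenyl ring on that carbonyl carbon would read in this assay.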